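The source may report more compounds than this note shows. Statements on the series, on what has been measured and on what is new or still open speak of the compounds shown alone.

Working notes on the series.

Compound 2 `O=c1ccn([C@@H]2O[C@H](COP(=O)(O)OP(=O)(O)O)[C@@H](O)[C@H]2O)c(SCCc2ccccc2)n1` gives 544 nM in an in vitro functional assay on 1321-N1 cells for agonist activity at P2Y purinoceptor 2 (Homo sapiens), read by scintillation proximity assay and inositol phosphate accumulation (a lower number here means that less compound is needed, a higher number that more compound is needed for the effect), which is the lowest of the two numbers shown. Its nearest neighbour, compound 3 `COc1nc(=O)ccn1[C@@H]1O[C@H](COP(=O)(O)O)[C@@H](O)[C@H]1O`, gives 9900 nM in this assay, a gap beyond the scatter. Compound 1 `Nc1nc(=O)ccn1[C@@H]1O[C@H](COP(=O)(O)O)[C@@H](O)[C@H]1O` reaches only > 100000 nM in this assay, a limit of the assay and not a number (the limit of > 100000 nM in this assay, at which 1 of the 3 values shown sits). Going by the values given here, the one measured step in the set, an at least 10-fold lower number from compound 1 to compound 3 (1.00 log units; beyond the scatter), is at least modest and comes from methoxy in place of amino on an aromatic carbon.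

Compound 4 `CSc1nc(=O)ccn1[C@@H]1O[C@H](COP(=O)(O)OP(=O)(O)O)[C@@H](O)[C@H]1O` is not yet measured. It differs from compound 2 by hydrogen in place of benzyl on a saturated chain carbon bound to a sulfur. Among the compounds with values here, no measured step mirrors this change: the only measured step alters a different group at a different place and so offers no direct guide to the size of the present one. The working expectation is nonetheless that the trimmed thioether will need more compound than compound 2, with a step of roughly a 3.7-fold higher number from compound 2 to compound 4 (0.57 log units; beyond the scatter) in this assay, towards a higher number and beyond the scatter. Compound 4 is therefore estimated at about 2000 nM in this assay, with a range from 500 nM to 8000 nM.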

Compound 4, half-maximal effective concentration: 523 nM
Compound 4: the middle estimate sits 3.8-fold (0.58 log units) above what was measured; measured number inside the range.
By their numbers in this assay, from the lowest: compounds 4 and 2 (each within the scatter of the next); then compound 3. At a limit, above all of these: compound 1.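

In this assay, going by these compounds alone, the first measured change on a saturated chain carbon bound to a sulfur reads as a 1.0-fold lower number from compound 2 to compound 4 (0.02 log units; within the scatter). The earlier compounds shown here held no step at this place, and this one shows that benzyl, with its six-membered aromatic ring, can give way to hydrogen without a difference that can be told from the scatter, so that phenethylsulfanyl and methylsulfanyl cannot be separated in this assay. Nothing in hand bears on why these two compounds cannot be separated.

The compounds shown leave open whether a longer chain, or an amine or a carboxylic acid carried on the chain, would also remain within the scatter of compound 2 and compound 4, since the only two chains compared here are phenethylsulfanyl and methylsulfanyl. Within the data shown here, they also leave open how methylsulfanyl compares with methoxy, as compound 3 and compound 4 differ in more than one place, and the single step at this position gives no guide to what replacing the whole sulfur-linked group with hydrogen would do.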